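Fluoro in place of hydrogen on a shared growth-inhibition series

This account rests on a few compounds, and the source may have more. Where it says the series, first, only, none or still open, it means among the compounds named here.

Measured compounds:
compound 1 `Oc1cccc2[nH]c(-c3ccc(-c4ccc(-c5ccccc5)cc4)cc3)nc12` — 1210 nM
compound 2 `Oc1cccc2[nH]c(-c3ccc(-c4ccc(-c5ccc(F)cc5)cc4)cc3)nc12` — 1220 nM
compound 3 `Cc1ccc2[nH]c(-c3ccc(-c4ccc(-c5ccccc5)cc4)cc3)nc2c1` — 2560 nM

In a functional assay on COLO 205 cells (Homo sapiens) for inhibition, read by sulforhodamine B assay (on this read-out lower numbers stand for stronger inhibition of growth and higher numbers for weaker inhibition of growth), compound 1 gives 1210 nM. Compound 2 differs from compound 1 only by fluoro in place of hydrogen on an aromatic carbon, and in this assay compound 2 gives 1220 nM; the step is a 1.0-fold higher number from compound 1 to compound 2 (0.00 log units; within the scatter). Compound 3 carries a different core; how the core of compound 1 and the core of compound 3 differ is not broken down here. In this assay compound 3 gives 2560 nM, the highest number of the three, with both its steps to compound 1 and to compound 2 beyond the scatter.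

Compound 4 `Cc1ccc2[nH]c(-c3ccc(-c4ccc(-c5ccc(F)cc5)cc4)cc3)nc2c1` is not yet measured. It differs from compound 3 by fluoro in place of hydrogen on an aromatic carbon, the same change as that from compound 1 to compound 2, on a place described in identical words. The change occurs only twice among these compounds, so one measured step is all that can guide an expectation. The step is expected to be a 1.0-fold higher number from compound 3 to compound 4 (0.01 log units; within the scatter), resting on compound 1 and compound 2, because a 1.0-fold higher number from compound 1 to compound 2 (0.00 log units; within the scatter). Compound 4 is therefore estimated at 2600 nM, between 1500 nM and 4600 nM.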

Compound 4, concentration for 50% growth inhibition: 100000 nM
Beside the measured number, compound 4's estimate is 38-fold (1.59 log units) below it, and the stated range ends below it.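

On the core of compound 3, phenyl to 4-fluorophenyl is far from a silent swap in this assay: the step is a 39-fold higher number from compound 3 to compound 4 (1.59 log units; beyond the scatter), a large one. The change therefore does not carry over unaltered between the two cores in this series: the same change on two cores in this assay, a 1.0-fold higher number (0.00 log units; within the scatter) from compound 1 to compound 2 and a 39-fold higher number (1.59 log units; beyond the scatter) from compound 3 to compound 4, 39-fold (1.59 log units) apart, beyond the scatter of two such steps. The step on the core of compound 1 is thus no reliable guide to the same change on the core of compound 3, but two pairs cannot show which difference between the cores goes with this split, or which of the two steps would be the more typical on a third core.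

Still open, as far as these compounds go, is whether a chloro, a methoxy or an amine in place of the fluoro on the core of compound 3 would give a step of similar size. Also open, from the compounds shown here alone, is whether the same groups on the core of compound 1 would leave the number as little moved as the fluoro does there.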